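The source may hold more compounds than are shown below. What is called first, only, known or untested is meant among the compounds shown, and "the series" means these compounds.

Within the data shown here, in a functional assay on HepG2 cells (Homo sapiens) for cytotoxicity, read by MTT assay, with a stated time of 48 h (on this read-out higher numbers stand for weaker inhibition and lower numbers for stronger inhibition), compound 1 (`Cc1ccc2oc(-c3ccccc3Cl)cc(=O)c2c1`) gives 6230 nM as the only number available, so there is no measured neighbour to rank it against. Compound 2 (`CCN(CC)Cc1ccc2oc(-c3ccc([N+](=O)[O-])cc3)cc(=O)c2c1`) cannot help here: its entry is "not determined" (no result reported) and offers nothing to compare. Compound 3 (`CC[N+](CC)(CC)Cc1ccc2oc(-c3ccccc3Cl)cc(=O)c2c1`) keeps the core of compound 1 and differs in one place, described as a group of 7 heavy atoms (6 carbon, 1 nitrogen; no ring) in place of a hydrogen atom, on a saturated chain carbon bound to an aromatic carbon on a saturated chain carbon bound to an aromatic carbon. The incoming group has no ring and carries a net charge of +1. Among the measured compounds shown here, no measured pair of compounds shows what a change of this kind does to the numbers in this assay here. The expectation therefore has a single anchor, compound 1 at 6230 nM in this series. The expected step of a 1.1-fold lower number from compound 1 to compound 3 (0.05 log units; within the scatter) is no larger than the usual scatter, with neither direction favoured, although a sizeable move either way remains possible. For compound 3 the estimate is 5500 nM and the expected range runs from 1500 nM to 20000 nM for now.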

Compound 3, half-maximal inhibitory concentration: 61000 nM
Estimate against measurement, compound 3: 11-fold (1.04 log units) below; the whole stated range lies below it.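

In this assay the group of 7 heavy atoms (6 carbon, 1 nitrogen; no ring), with a net charge of +1, replaces a hydrogen atom on a saturated chain carbon bound to an aromatic carbon and gives a 9.8-fold higher number from compound 1 to compound 3 (0.99 log units; beyond the scatter), which means weaker inhibition. Among these compounds, this is the first measured sign that the read-out responds to a change at this place, since the step lies beyond the usual scatter and the earlier compounds offered no pair to compare. The compounds shown give no measurement that explains the step.

Among the compounds shown here, with only this one pair, the size of the incoming group and its charge cannot be told apart, so it remains open which of the two goes with the higher number. For the compounds shown here, a hydroxyl group, a carboxylic acid or a shorter uncharged chain at the same place on the core of compound 1 would help to show whether any larger group gives a step of this kind, or only a charged group like the one in compound 3.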